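Trimethoxyphenyl Replaces Hydroxyphenyl on the Shared Core

The source may hold more compounds than are shown below. What is called first, only, known or untested is meant among the compounds shown, and "the series" means these compounds.

Of the compounds shown here, three built on one shared core have been tested in a functional assay on U-87MG ATCC cells (Homo sapiens) for cytotoxicity, read by MTT assay, with a stated time of 72 h; a lower number here means a stronger inhibitor, a higher number a weaker inhibitor. Compound 1 `COc1ccc(OC)c(/C=N/NC(=O)Nc2ccc(Oc3ccnc(-c4nncn4CCN(C)C)c3)c(F)c2)c1` gives 6400 nM. Compound 2 `CN(C)CCn1cnnc1-c1cc(Oc2ccc(NC(=O)N/N=C/c3ccc(Cl)cc3)cc2F)ccn1` gives 1370 nM. Compound 3 `CN(C)CCn1cnnc1-c1cc(Oc2ccc(NC(=O)N/N=C/c3ccc(O)cc3)cc2F)ccn1` gives 7750 nM. Among the measured compounds shown here, compound 3 carries the highest number of the three, though its gap to compound 1 is within the scatter; only the step of a 5.7-fold higher number from compound 2 to compound 3 (0.75 log units; beyond the scatter) sets it clearly apart from another member.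

The new compound 4 `COc1cc(/C=N/NC(=O)Nc2ccc(Oc3ccnc(-c4nncn4CCN(C)C)c3)c(F)c2)cc(OC)c1OC` differs from compound 3 in a single place: 3,4,5-trimethoxyphenyl in place of 4-hydroxyphenyl on a carbon with a double bond to nitrogen. Two earlier steps bear on this change. The step of a 1.2-fold higher number from compound 1 to compound 3 (0.08 log units; within the scatter) shows that the 2,5-dimethoxyphenyl and the 4-hydroxyphenyl cannot be told apart on this read-out. The step of a 5.7-fold higher number from compound 2 to compound 3 (0.75 log units; beyond the scatter) shows that the 4-chlorophenyl alone gave a clearly lower number. Compound 4 carries methoxy groups on its ring, as compound 1 does, rather than chloro, so a step no larger than the scatter is expected, a 1.4-fold lower number from compound 3 to compound 4 (0.15 log units; within the scatter). Compound 4 is therefore estimated at 5500 nM, with a range from 2200 nM to 14000 nM.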

Compound 4, half-maximal inhibitory concentration: 22500 nM
The estimate for compound 4 lay 4.1-fold (0.61 log units) below the measured number, and the stated range ends below it.
By their numbers in this assay, from the lowest: compound 2; then compounds 1 and 3 (each within the scatter of the next); then compound 4.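

In this assay, the 3,4,5-trimethoxyphenyl group on a carbon with a double bond to nitrogen gives a result that stands apart from the two rings that could not be told apart before, with both steps beyond the scatter (a 2.9-fold higher number from compound 3 to compound 4 (0.46 log units; beyond the scatter); a 3.5-fold higher number from compound 1 to compound 4 (0.55 log units; beyond the scatter)). Among the compounds shown here, its step from the 4-chlorophenyl group is the largest at this position so far (a 16-fold higher number from compound 2 to compound 4 (1.22 log units; beyond the scatter)), which makes compound 4 the weakest of the four and shows that this one place can shift the number widely while the rest of the structure stays the same. Methoxy groups therefore do not all land in one place on this read-out, as the 2,5-dimethoxyphenyl of compound 1 stays within the scatter of the 4-hydroxyphenyl of compound 3, and nothing shown here explains the difference.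

The compounds shown do not separate the number of methoxy groups from where they sit, so a phenyl ring with a single methoxy group would be informative. On these data alone, how a bromo, an amine or a carboxylic acid on the phenyl ring would compare also remains open.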